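Shortening the Acetamide Arm of Compound 2

The source may hold more compounds than are shown below. What is called first, only, known or untested is meant among the compounds shown, and "the series" means these compounds.

Compound 1 `COc1ccc(Nc2nc(NCc3cccnc3N(C)S(C)(=O)=O)c3c(F)c[nH]c3n2)cc1OC` gives 54800 nM in a functional assay on SMMC-7721 cells (Homo sapiens) for inhibition, read by MTT assay, with a stated time of 48 h; a higher number here means a weaker inhibitor, a lower number a stronger inhibitor.
Compound 2 `CC(=O)NCc1cccc(Nc2nc(NCc3cccnc3N(C)S(C)(=O)=O)c3c(F)c[nH]c3n2)c1` gives 21700 nM in this assay.

Compound 2 holds the lower of the two numbers shown, and the one measured step is a 2.5-fold lower number from compound 1 to compound 2 (0.40 log units; beyond the scatter). Compound 3 `CC(=O)Nc1cccc(Nc2nc(NCc3cccnc3N(C)S(C)(=O)=O)c3c(F)c[nH]c3n2)c1` has not been measured yet. It differs from compound 2 in one place: acetamido in place of acetamidomethyl on an aromatic carbon. Within the data shown here, the single measured step exchanges the entire group sitting on the nitrogen of the shared core for a different one, so it does not bear on shortening the acetamide arm while the ring itself stays unchanged. Among the measured compounds shown here, no measured pair shows that change. With nothing pointing in either direction, compound 3 is expected to land close to compound 2, a step of a 1.1-fold lower number from compound 2 to compound 3 (0.04 log units; within the scatter) that should stay within the scatter. Compound 3 is therefore estimated at 20000 nM in this assay, with a range from 8000 nM to 50000 nM.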

Compound 3, half-maximal inhibitory concentration: 16000 nM
For compound 3 the middle estimate is 1.3-fold (0.10 log units) above the measured one; the measured number falls inside the stated range.
By their numbers in this assay, from the lowest: compounds 3 and 2 (each within the scatter of the next); then compound 1.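

Moving from acetamidomethyl to acetamido on this aromatic carbon gives a 1.4-fold lower number from compound 2 to compound 3 (0.13 log units; within the scatter) in this assay, so these numbers do not separate the two arm lengths at this place, meta to a large group. The comparison with the dimethoxy compound gives a 3.4-fold lower number from compound 1 to compound 3 (0.53 log units; beyond the scatter), which means that 3-acetamidophenyl, like 3-(acetamidomethyl)phenyl before it, reads as a stronger inhibitor than 3,4-dimethoxyphenyl on that nitrogen, and neither of the three compounds goes against this. Nothing measured here accounts for these numbers.

Still open, from the compounds shown here alone, is whether the amide itself matters, since a plain amine or a carboxylic acid at this place could be compared directly with the acetamido group. A longer chain, such as acetamidoethyl, would show whether the arm length stays this unimportant further out.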